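A few compounds are considered here, and "the series" means these few. Any claim that something is new, unique, unknown or untested is made for them only; others in the source may bear on it.

Measured compounds:
Compound 1, `Cc1cn2c(-c3cn[nH]c3)cnc2c(Nc2cc(Cc3ncccn3)ns2)n1`: 701 ng.h/mL
Compound 2, `Cc1cn2c(-c3cn[nH]c3)cnc2c(Nc2cc(Cc3ccncc3)ns2)n1`: "not determined" (no result reported)

Compound 1 and compound 2 share one core and differ only in the six-membered ring carried on the chain carbon. Going by the values given here, in an ADME assay on the whole organism for pharmacokinetics, with Rattus norvegicus as the target, with a stated time of 6 h, at a dose of 10 mg/kg by the oral route (a lower number here means less compound in the circulation, a higher number more compound in the circulation at the dose given), compound 1 gives 701 ng.h/mL, while for compound 2 the result is "not determined" (no result reported), so compound 2 stands on no single number and no step between the two can be read.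

Compound 3, `Cc1ccnc(Cc2cc(Nc3nc(C)cn4c(-c5cn[nH]c5)cnc34)sn2)c1`, is compound 2 with 4-methylpyridin-2-yl in place of pyridin-4-yl on a saturated chain carbon bound to an aromatic carbon. Among the compounds with values here, no measured step covers this change, and with compound 2 itself unquantified there is nothing to set its size against; a shift of modest size in this assay, in either direction, would be the sober expectation, with no firm ground for more than that. Resting on compound 1, which gives 701 ng.h/mL, compound 3 is expected to give about 500 ng.h/mL in this assay, within a range from 100 ng.h/mL to 2500 ng.h/mL.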

Compound 3, area under the concentration-time curve: 1850 ng.h/mL
Compound 3: the middle estimate sits 3.7-fold (0.57 log units) below what was measured, and the stated range covers the measured number.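

In this assay, exchanging the six-membered ring on the chain carbon gives a 2.6-fold higher number from compound 1 to compound 3 (0.42 log units; beyond the scatter), which shows that the ring carried at this position can move the read-out. Going by these compounds alone, this is the only step that can be read, as compound 2 has no number to set against compound 3. Nothing shown here accounts for the rise.

The step alters the ring and adds a methyl group in one change, so the compounds shown do not separate the two contributions. From the compounds shown here alone, it remains open how the result would stand with plain pyridin-2-yl, or with methoxy in place of the methyl group on the pyridine ring of compound 3.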